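Sulfonyl aryl fluorination on a low-inhibition core

The source may hold more compounds than are shown below. What is called first, only, known or untested is meant among the compounds shown, and "the series" means these compounds.

Three compounds of the series have numbers in an assay on isolated protein for displacement of a labelled ligand from metabotropic glutamate receptor 5 (Homo sapiens), with a stated time of 60 min, tested at 1 uM; on this read-out higher numbers stand for more inhibition at the one concentration tested (going by the name of the read-out) and lower numbers for less inhibition. Compound 1 `CC1CCN(c2c(S(=O)(=O)c3ccccc3)cnc3ccccc23)CC1` gives 89.2% in this assay. Compound 2 `CC1CCN(c2c(S(=O)(=O)c3ccc(Cl)c(Cl)c3)cnc3ccc(Cl)cc23)CC1` gives 86% in this assay; its structure differs from compound 1 in more than one place, so the two values are simply noted side by side and lie within the scatter of each other. Compound 3 `CC1CCN(c2c(S(=O)(=O)c3ccccc3)cnc3c(F)cccc23)CC1` gives 13% in this assay and stands lowest of the three, the others well above it beyond the scatter. For the measured compounds named here, the single one-place step known is a number 76.2 percentage points lower from compound 1 to compound 3 (beyond the scatter), which is large.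

Compound 4 `CC1CCN(c2c(S(=O)(=O)c3ccc(F)c(F)c3)cnc3c(F)cccc23)CC1` is not yet measured. Its change from compound 3 is 3,4-difluorophenyl in place of phenyl on a sulfonyl sulfur. Going by the values given here, no measured pair differs in only this way, so no step bears on it directly; the only comparison touching the phenyl on the sulfonyl sulfur is between compound 1 and compound 2, whose values show no difference beyond the scatter, though that pair changes two places. The expectation is therefore a step of a number 5 percentage points higher from compound 3 to compound 4 (within the scatter), within the scatter, with compound 3 remaining the reference. Compound 4 is estimated at 18%, in a range from 4% to 42%.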

Compound 4, a percentage reported as inhibition, at one concentration (the size of the read-out at that concentration, not a potency): 93%
Compound 4: the middle estimate sits 75 percentage points below what was measured; measured number outside the range, above it.
By their numbers in this assay, from the lowest: compound 3; then compounds 2, 1 and 4 (each within the scatter of the next).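

In this assay, for the compounds shown here, the phenyl on a sulfonyl sulfur proves to be a place that responds strongly on the core of compound 3: 3,4-difluorophenyl in place of phenyl gives a number 80 percentage points higher from compound 3 to compound 4 (beyond the scatter) and is the first one-place change to raise the number. Its size is large, as is that of the earlier step, a number 76.2 percentage points lower from compound 1 to compound 3 (beyond the scatter), but it runs the opposite way, so the low number of compound 3 at 13% is not fixed by the fluoro on the aromatic carbon of the core: compound 4 carries that same fluoro and gives 93% in the same read-out. Nothing at hand bears on why this exchange on the sulfonyl sulfur has so large an effect.

The compounds shown do not separate the contributions of the fluorines within 3,4-difluorophenyl, and they do not say how this group behaves on the core of compound 1 without the fluoro. From the compounds shown here alone, whether a methoxyphenyl, a pyridine ring or a small alkyl chain on the sulfonyl sulfur would also restore the number on the core of compound 3 remains open.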